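Pyrazin-2-yl in place of 4-chlorophenyl: compound 3

The source may hold more compounds than are shown below. What is called first, only, known or untested is meant among the compounds shown, and "the series" means these compounds.

Among the measured compounds shown here, compound 1 `Nc1ccccc1NC(=O)c1ccc(CSC(=S)N2CCN(c3ccc(Cl)cc3)CC2)cc1` gives 51.2% in a functional assay on HeLa cells (Homo sapiens) for antiproliferative activity, read by CCK-8 assay, with a stated time of 72 h, tested at 2 uM (on this read-out higher numbers stand for a stronger effect at the one concentration tested and lower numbers for a weaker effect), the lowest of the two numbers measured so far. Compound 2 `Nc1ccccc1NC(=O)c1ccc(CSC(=S)N2CCN(c3ccccc3)CC2)cc1` gives 62.2% in this assay; the step of a number 11 percentage points higher from compound 1 to compound 2 (beyond the scatter) is hydrogen in place of chloro on an aromatic carbon. Compound 3 `Nc1ccccc1NC(=O)c1ccc(CSC(=S)N2CCN(c3cnccn3)CC2)cc1` differs from compound 1 by pyrazin-2-yl in place of 4-chlorophenyl on an amine nitrogen in a ring, a change at the same amine nitrogen in a ring but to another aromatic group. For the measured compounds named here, only the step to compound 2 bears on it, and that step was modest. The expected step is therefore a number 5.8 percentage points higher from compound 1 to compound 3 (within the scatter), small and upward, close to the scatter. The estimate for compound 3 is 57%, within 40% to 72%.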

Compound 3, a percentage reported as inhibition, at one concentration (the size of the read-out at that concentration, not a potency): 70.4%
Beside the measured number, compound 3's estimate is 13.4 percentage points below it, within the range that was stated.
By their numbers in this assay, from the lowest: compound 1; then compounds 2 and 3 (each within the scatter of the next).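

Pyrazin-2-yl on the amine nitrogen in a ring gives a number 19.2 percentage points higher from compound 1 to compound 3 (beyond the scatter) and so shows that this position accepts a ring with 2 hetero atoms in place of a ring of carbon only. Against phenyl, a number 8.2 percentage points higher from compound 2 to compound 3 (within the scatter) leaves the two groups unseparated, so the gain over 4-chlorophenyl cannot be assigned to the ring nitrogens rather than to the loss of chloro. No measured evidence on the cause of this result is at hand. Open, from the compounds shown here alone, is whether pyridin-2-yl, cyclohexyl or a plain methyl on this nitrogen holds the number.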